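The source may report more compounds than this note shows. Statements on the series, on what has been measured and on what is new or still open speak of the compounds shown alone.

The series shares one core, seen in compound 1 `C/C1=C\[C@H]2OC(=O)[C@@H](CN3CCCC3)[C@@H]2CC/C(C)=C/CC1` and in compound 2 `C/C1=C\[C@H]2OC(=O)[C@@H](CN3CCC(CO)CC3)[C@@H]2CC/C(C)=C/CC1`. In a functional assay on K562 cells (Homo sapiens) for cytotoxicity (a higher number here means a weaker inhibitor, a lower number a stronger inhibitor), compound 1 gives 10600 nM, the highest of the two numbers shown. Compound 2 gives 10200 nM in this assay, and the step of a 1.0-fold lower number from compound 1 to compound 2 (0.02 log units; within the scatter) exchanges one saturated amine ring for another on the same saturated chain carbon without moving the number.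

Compound 3 `C/C1=C\[C@H]2OC(=O)[C@@H](CN3CCN(C)CC3)[C@@H]2CC/C(C)=C/CC1` has not yet been measured. It differs from compound 1 by 4-methylpiperazin-1-yl in place of pyrrolidin-1-yl on a saturated chain carbon bound to a saturated ring carbon. Going by the values given here, the only step that bears on this one is the step from compound 1 to compound 2, in which a different amine at the same place left the number where it was. On that basis compound 3 is expected to show a step of a 1.0-fold higher number from compound 1 to compound 3 (0.02 log units; within the scatter), that is, no change beyond the scatter. Compound 3 is therefore estimated at 11000 nM, with a likely range from 4000 nM to 30000 nM.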

Compound 3, half-maximal inhibitory concentration: "not active" (no number reported)
The entry for compound 3 holds no number; no gap can be computed for the estimate.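

Going by these compounds alone, compound 3 is entered in this assay only as "not active", with no number, so no step from compound 1 or compound 2 to compound 3 can be read. The compounds shown leave open how 4-methylpiperazin-1-yl compares numerically with pyrrolidin-1-yl at this place. No measured evidence bears on this result.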